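The source may report more compounds than this note shows. Statements on the series, on what has been measured and on what is new or still open speak of the compounds shown alone.

Measured compounds in this series:

compound 1, `CC(C)(C)C#Cc1cc(N(C(=O)[C@H]2CC[C@H](C)CC2)[C@H]2CC[C@H](Oc3ccccn3)CC2)c(C(=O)O)s1`: > 20000 nM
compound 2, `CC1=CC[C@H](C(=O)N(c2cc(C#CC(C)(C)C)sc2C(=O)O)[C@H]2CC[C@](O)(CO[C@H]3CCOC3)CC2)CC1`: > 20000 nM
compound 3, `CC(C)(C)C#Cc1cc(N(C(=O)[C@H]2CC[C@H](C)CC2)[C@H]2CC[C@@](O)(CO[C@H]3CCOC3)CC2)c(C(=O)O)s1`: > 20000 nM

In an ADME assay on MT4 cells (Homo sapiens) for cytotoxicity, with a stated time of 5 days (a lower number here means that less compound is tolerated, a higher number that more compound is tolerated), compound 1 gives > 20000 nM, which is a limit of the assay and not a number. Compound 2 gives > 20000 nM, again only a limit. Compound 3 gives > 20000 nM, a limit as well. The three results therefore tell the same thing: the limit of > 20000 nM in this assay, at which 3 of the 3 values shown sit. Compound 1 stands level with the other two at the top of what this assay reports, and no true difference between any pair of these compounds can be read from them. Among the measured compounds shown here, no pair among the measured compounds differs in one place only, so the data give no measured step that would show how a single change moves the number.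

Compound 4, `CC(C)(C)C#Cc1cc(N(C(=O)[C@H]2CC[C@H](C)CC2)[C@H]2CC[C@H](OC3CCOC3)CC2)c(C(=O)O)s1`, has not been measured. Against compound 1 the change is oxolan-3-yl in place of pyridin-2-yl on an oxygen on a saturated carbon. The shared core, the alkyne-bearing substituent, the carboxylic acid and the amide side are all kept. Since every compound shown sits at the limit, the step from compound 1 to compound 4 is expected to be none beyond the scatter, a step that the limit leaves unreadable from compound 1 to compound 4. For compound 4 the expected value in this assay is 30000 nM, with a range of 15000 nM to 60000 nM, and a limit rather than a number is the most likely outcome.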

Compound 4, half-maximal cytotoxic concentration: > 20000 nM
Compound 4: a limit, no number; the forecaster's own chance of this, stated with the estimate: 80%; the middle value does not contradict the limit.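

No new step can be read between compound 1 and compound 4, as both results are limits and not numbers, so the exchange of pyridin-2-yl for oxolan-3-yl shows no measurable size: the limit of > 20000 nM in this assay, at which 4 of the 4 values shown sit.

The compounds shown leave open where the true cytotoxic concentration of each lies in this assay, and whether any structural change moves it.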